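The source may hold more compounds than are shown below. What is called first, only, known or untested is meant among the compounds shown, and "the series" means these compounds.

The measured compounds:
Compound 1, `O=C(NCCCCc1ccccc1)c1cccc(C2SCC(=O)N2c2ccccc2)c1`, in a functional assay on MG-63 cells (Homo sapiens) for inhibition, read by CCK-8 assay, with a stated time of 72 h, tested at 1 uM (on this read-out lower numbers stand for less inhibition and higher numbers for more inhibition at the one concentration tested (going by the name of the read-out)), gives 89%.
Compound 2, `CCN1C(=O)CSC1c1cccc(C(=O)NCCCCc2ccccc2)c1`, gives 0%.
Compound 3, `O=C(NCCCCc1ccccc1)c1cccc(C2OCC(=O)N2c2cccc(F)c2)c1`, gives 66%.

Among these three numbers compound 1 stands highest; compound 3 is nearest to it and compound 2 furthest below it. For the measured compounds named here, the only single-place step recorded, a number 89 percentage points lower from compound 1 to compound 2 (beyond the scatter), concerns ethyl in place of phenyl on an amide-type nitrogen in a ring and was large. Compound 4, `O=C(NCCCCc1ccccc1)c1cccc(C2SCC(=O)N2c2ccccc2F)c1`, has not yet been measured. It differs from compound 1 by fluoro in place of hydrogen on an aromatic carbon. Going by the values given here, no measured step bears directly on this change: the step from compound 1 to compound 2 replaces the whole phenyl rather than adding a fluoro group, and compound 3, although it carries a fluoro group, also differs from compound 1 in its core, so its lower value cannot be read as the effect of fluorine alone. A step of no more than the usual scatter is therefore expected in this assay, in either direction. Compound 4 is estimated at 82%, between 55% and 96%, which means an expected step of a number 7 percentage points lower from compound 1 to compound 4 (within the scatter).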

Compound 4, a percentage reported as inhibition, at one concentration (the size of the read-out at that concentration, not a potency): 92%
Compound 4: the middle estimate sits 10 percentage points below what was measured; the range from low to high includes it.
By their numbers in this assay, from the lowest: compound 2; then compound 3; then compounds 1 and 4 (each within the scatter of the next).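

In this assay the change to 2-fluorophenyl amounts to a number 3 percentage points higher from compound 1 to compound 4 (within the scatter) and so shows that this aromatic carbon, ortho to a large group, accepts fluoro in place of hydrogen without a change beyond the scatter. The earlier compounds shown here could not show this, as compound 3 carries fluorine but also differs from compound 1 in its core. The step of a number 92 percentage points higher from compound 2 to compound 4 (beyond the scatter) shows that the large gap to the ethyl compound also holds when the ring on that amide-type nitrogen bears fluoro, and nothing available explains why the fluoro group is accepted here.

On these data alone, whether a larger group at this place, such as methoxy, trifluoromethyl or an amine, would be accepted as well remains open. A reading at a single concentration also leaves open whether compound 1 and compound 4 differ in potency.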